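Same halophenyl swap, repeated on a methylated core

The compounds below may be only part of what the source reports. "The series", "measured", "known", "first", "only" and "open" are said of these compounds alone.

Compound 1 `O=C(Nc1ccc(Oc2ccnc3[nH]ccc23)cc1)c1nn(-c2ccc(Br)cc2F)ccc1=O` is the starting point of this small series. In a functional assay on MCF7 cells (Homo sapiens) for cytotoxicity, read by MTT assay, with a stated time of 72 h (a higher number here means a weaker inhibitor, a lower number a stronger inhibitor), compound 1 gives 17900 nM. Compound 2 `O=C(Nc1ccc(Oc2ccnc3[nH]ccc23)cc1)c1nn(-c2ccc(Cl)c(F)c2)ccc1=O` differs from compound 1 only by 4-chloro-3-fluorophenyl in place of 4-bromo-2-fluorophenyl on an aromatic nitrogen. In this assay compound 2 gives 3110 nM, so that a 5.8-fold lower number from compound 1 to compound 2 (0.76 log units; beyond the scatter). Compound 3 `Cn1ccc2c(Oc3ccc(NC(=O)c4nn(-c5ccc(Br)cc5F)ccc4=O)cc3)ccnc21` differs from compound 1 by methyl in place of hydrogen on an aromatic nitrogen, a change that leaves the halophenyl untouched. In this assay compound 3 gives 19800 nM, and a 1.1-fold higher number from compound 1 to compound 3 (0.04 log units; within the scatter). Compound 4 `Cn1ccc2c(Oc3ccc(NC(=O)c4nn(-c5ccc(Cl)c(F)c5)ccc4=O)cc3)ccnc21` has not yet been measured. Going by the values given here, it differs from compound 3 by 4-chloro-3-fluorophenyl in place of 4-bromo-2-fluorophenyl on an aromatic nitrogen, which is the same change as the one between compound 1 and compound 2, now carried out on the core of compound 3 rather than on the core of compound 1. The two cores differ by methyl in place of hydrogen on an aromatic nitrogen. For compound 4 a step of a 5.7-fold lower number from compound 3 to compound 4 (0.75 log units; beyond the scatter) is expected, because a 5.8-fold lower number from compound 1 to compound 2 (0.76 log units; beyond the scatter) was seen for the identical change, and because a 1.1-fold higher number from compound 1 to compound 3 (0.04 log units; within the scatter) shows that the methyl itself hardly moved the number. Compound 4 is therefore estimated at 3500 nM, with a likely range from 1500 nM to 8500 nM.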

Compound 4, half-maximal inhibitory concentration: 16800 nM
Beside the measured number, compound 4's estimate is 4.8-fold (0.68 log units) below it, and the stated range ends below it.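

The halophenyl swap that helped on the core of compound 1 did not carry over to the methylated core, where it gives a 1.2-fold lower number from compound 3 to compound 4 (0.07 log units; within the scatter) in this assay: the same change on two cores in this assay, a 5.8-fold lower number (0.76 log units; beyond the scatter) from compound 1 to compound 2 and a 1.2-fold lower number (0.07 log units; within the scatter) from compound 3 to compound 4, 4.9-fold (0.69 log units) apart, beyond the scatter of two such steps

Seen from the other side, the methyl gives a 5.4-fold higher number from compound 2 to compound 4 (0.73 log units; beyond the scatter), although it made no clear difference when the 4-bromo-2-fluorophenyl group was present: the same change on two cores in this assay, a 1.1-fold higher number (0.04 log units; within the scatter) from compound 1 to compound 3 and a 5.4-fold higher number (0.73 log units; beyond the scatter) from compound 2 to compound 4, 4.9-fold (0.69 log units) apart, beyond the scatter of two such steps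

Across these four compounds, the two changes therefore do not act independently, and the effect of each depends on the other, but the numbers do not show why this happens or whether it would hold for any other pair of groups.

As far as these compounds go, the swap alters the halogen and the placing of the fluorine together, and which of the two matters stays open. Also open, from the compounds shown here alone, is whether a plain phenyl on the aromatic nitrogen, or an ethyl in place of the methyl, would show the same dependence.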